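The compounds below may be only part of what the source reports. "The series", "measured", "known", "first", "only" and "open" are said of these compounds alone.

Compound 1 `COC(CNc1ccccc1CO)n1cc(F)c(=O)[nH]c1=O` stands at the weaker end of the two compounds measured in a functional assay on MCF7 cells (Homo sapiens) for antiproliferative activity; on this read-out lower numbers stand for stronger inhibition and higher numbers for weaker inhibition: compound 1 gives 36000 nM, whereas compound 2 `Nc1ccc(S(=O)(=O)N2CC(n3cc(F)c(=O)[nH]c3=O)OCc3ccccc32)cc1` gives 14400 nM, a gap beyond the usual scatter. Compound 3 `COC(CN(c1ccccc1CO)S(=O)(=O)c1ccccc1N)n1cc(F)c(=O)[nH]c1=O` differs from compound 1 by (2-aminophenyl)sulfonyl in place of hydrogen on a nitrogen on an aromatic ring. Compound 2 also carries a sulfonyl-linked aminophenyl group on its ring nitrogen and sits lower than compound 1. A modest step toward stronger inhibition is therefore expected, a 2.4-fold lower number from compound 1 to compound 3 (0.38 log units; beyond the scatter). Compound 3 is estimated at 15000 nM in this assay, within a range of 5000 nM to 45000 nM.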

Compound 3, half-maximal inhibitory concentration: > 100000 nM
Compound 3 was reported as a limit; the forecaster's own chance of this, stated with the estimate: 10%; middle value at least 6.6-fold (0.82 log units) away from the limit.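

In this assay, (2-aminophenyl)sulfonyl in place of hydrogen on the nitrogen on an aromatic ring brings an at least 2.7-fold higher number from compound 1 to compound 3 (0.44 log units; beyond the scatter), so on the core of compound 1 this change weakens inhibition rather than strengthening it. Among these compounds, until now this nitrogen had been seen only with hydrogen, and the result shows that the read-out responds to what it carries. The value of compound 3 is a limit, not a number: the limit of > 100000 nM in this assay, at which 1 of the 3 values shown sits.

Going by these compounds, how far the step extends past that limit remains open. So does whether a smaller group on this nitrogen, such as methyl or acetyl, would raise the number or lower it.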